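The compounds below may be only part of what the source reports. "The series", "measured", "known", "first", "only" and "open" are said of these compounds alone.

Measured so far:
- compound 1 `O=C(Nc1cccc(-n2cc(-c3ccncc3)c(-c3ccc(Cl)c(O)c3)n2)c1)Nc1cccc(C(F)(F)F)c1`: 1340 nM
- compound 2 `COc1cc(-c2nn(-c3cccc(NC(=O)c4cccc(C(F)(F)F)c4)c3)cc2-c2ccncc2)ccc1Cl`: 1570 nM
- compound 3 `O=C(Nc1cccc(-n2cc(-c3ccncc3)c(-c3ccc(Cl)c(O)c3)n2)c1)Nc1ccc(Cl)c(Cl)c1`: 1030 nM

All three were tested in a functional assay on RPMI-8226 cells (Homo sapiens) for inhibition, read by sulforhodamine B assay, with a stated time of 48 h; a lower number here means a stronger inhibitor, a higher number a weaker inhibitor. Compound 1 holds the second highest of the three numbers, yet its value, the value of compound 2 and the value of compound 3 all lie within the usual scatter of one another, so nothing separates them with confidence.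

Compound 4 `O=C(Nc1cccc(-n2cc(-c3ccncc3)c(-c3ccc(Cl)c(O)c3)n2)c1)Nc1cc(C(F)(F)F)cc(C(F)(F)F)c1` is made from compound 1 by one change: trifluoromethyl in place of hydrogen on an aromatic carbon. Going by the values given here, the only measured step that touches the same part of the molecule is the exchange of the aryl group on the amide-type nitrogen, where a 1.3-fold lower number from compound 1 to compound 3 (0.11 log units; within the scatter). Compound 2 differs from compound 1 in more than one place, so it offers no single-change comparison; its value simply sits close to that of compound 1.

Among the compounds with values here, with the one relevant step lying within the scatter, no step beyond the scatter is expected from compound 1 to compound 4 in this assay, that is a 1.1-fold lower number from compound 1 to compound 4 (0.05 log units; within the scatter). Compound 4 is therefore estimated at 1200 nM, with a range of 500 nM to 3000 nM.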

Compound 4, half-maximal inhibitory concentration: 480 nM
Compound 4: the middle estimate sits 2.5-fold (0.40 log units) above what was measured; the whole stated range lies above it.
By their numbers in this assay, from the lowest: compound 4; then compounds 3, 1 and 2 (each within the scatter of the next).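

In this assay, trifluoromethyl in place of hydrogen on the aromatic carbon meta to the existing trifluoromethyl group gives a 2.8-fold lower number from compound 1 to compound 4 (0.45 log units; beyond the scatter) and so moves the number beyond the scatter. The other single change shown, the exchange of the aryl group on the amide-type nitrogen, gives a 1.3-fold lower number from compound 1 to compound 3 (0.11 log units; within the scatter) and stays within the scatter, so this new step is the first sign that substitution on this ring can shift the number in this assay. Nothing available here bears on why the number falls.

On these data alone, it remains open whether trifluoromethyl itself is needed at this carbon, or whether a methyl group, a nitrile or a dimethylamino group there would shift the number in the same way. This single step also cannot show how far the shift would carry over to a different core.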